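A Fluorine Repositioned on the Amide Aryl Ring

The compounds below may be only part of what the source reports. "The series", "measured", "known", "first", "only" and "open" are said of these compounds alone.

Compound 1 `O=C(Nc1cccc(-c2oc3cc(-c4ccc(F)cc4)ccc3c(=O)c2O)c1)c1ccccc1F` gives 4410 nM. Compound 2 `O=C(Nc1cccc(-c2oc3cc(-c4ccc(F)cc4)ccc3c(=O)c2O)c1)c1ccc(F)cc1` gives 6930 nM. Compound 3 `Cc1ccccc1C(=O)Nc1cccc(-c2oc3cc(-c4ccc(F)cc4)ccc3c(=O)c2O)c1` gives 17600 nM.

All three share the same core and differ only in the aryl group on the carbonyl carbon of the amide. In a functional assay on A549 cells (Homo sapiens) for antiproliferative activity, read by CCK-8 assay, with a stated time of 72 h (a lower number here means a stronger inhibitor, a higher number a weaker inhibitor), compound 3 stands as the highest of the three numbers, so it is the weakest inhibitor in this set; its nearest neighbour is compound 2, and compound 1 lies furthest from it.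

Compound 4 `O=C(Nc1cccc(-c2oc3cc(-c4ccc(F)cc4)ccc3c(=O)c2O)c1)c1cccc(F)c1` arises from compound 3 by 3-fluorophenyl in place of 2-methylphenyl on a carbonyl carbon. Within the data shown here, two measured steps bear on this. The first, a 2.5-fold higher number from compound 2 to compound 3 (0.40 log units; beyond the scatter), shows that replacing a fluorophenyl by a methylphenyl weakened inhibition. The second, a 1.6-fold higher number from compound 1 to compound 2 (0.20 log units; within the scatter), shows that moving the fluorine on the phenyl ring changed little. Reversing the methyl-for-fluorine exchange is therefore expected to bring the number back toward those of compound 1 and compound 2, and the new fluorine position is not expected to matter much on its own.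

Compound 4 is therefore expected to show a 3.2-fold lower number from compound 3 to compound 4 (0.51 log units; beyond the scatter) in this assay. The estimated value of compound 4 is 5500 nM, with a range from 2500 nM to 12000 nM.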

Compound 4, half-maximal inhibitory concentration: 15400 nM
The estimate for compound 4 lay 2.8-fold (0.45 log units) below the measured number; measured number outside the range, above it.
By their numbers in this assay, from the lowest: compounds 1 and 2 (each within the scatter of the next); then compounds 4 and 3 (each within the scatter of the next).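

In this assay, the 3-fluorophenyl group on the carbonyl carbon cannot be told apart from 2-methylphenyl (a 1.1-fold lower number from compound 3 to compound 4 (0.06 log units; within the scatter)), so carrying a fluorine on this ring does not in itself place a compound with compound 1 and compound 2. Among these compounds, the place of the fluorine on the ring therefore counts for more than the earlier compounds suggested: 3-fluorophenyl gives a weaker inhibitor than 4-fluorophenyl (a 2.2-fold higher number from compound 2 to compound 4 (0.35 log units; beyond the scatter)) and than 2-fluorophenyl (a 3.5-fold higher number from compound 1 to compound 4 (0.54 log units; beyond the scatter)), although the step between those last two groups stayed within the scatter (a 1.6-fold higher number from compound 1 to compound 2 (0.20 log units; within the scatter)). Nothing available here accounts for why the 3-fluorophenyl compound departs from the other two fluorophenyl compounds.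

The compounds shown leave open how a phenyl group with no substituent on this carbonyl carbon would compare, which would show whether the fluorine in compound 1 and compound 2 helps or the fluorine in compound 4 and the methyl in compound 3 hinder. They also leave open whether a chlorophenyl or aminophenyl group at this position would follow the same dependence on ring position that the three fluorophenyl compounds show.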